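Shortening the aromatic substituent from hexyloxy to methyl

The source may report more compounds than this note shows. Statements on the series, on what has been measured and on what is new or still open speak of the compounds shown alone.

The three measured compounds share the core of compound 1 `CCCCOc1ccc(NS(=O)(=O)c2ccc(N3CCNC3=O)cc2)cc1`, which in a functional assay on M21 cells (Homo sapiens) for antiproliferative activity, read by sulforhodamine B assay, with a stated time of 48 h (on this read-out higher numbers stand for weaker inhibition and lower numbers for stronger inhibition), gives 580 nM. Compound 2 `COc1cccc(NS(=O)(=O)c2ccc(N3CCNC3=O)cc2)c1` gives 65 nM in this assay. Compound 3 `CCCCCCOc1ccc(NS(=O)(=O)c2ccc(N3CCNC3=O)cc2)cc1` returns only a limit in this assay, > 1000 nM, so for compound 3 there is no number, only a bound. Among the compounds with values here, the single one-place step among the measured compounds runs an at least 1.7-fold higher number from compound 1 to compound 3 (0.23 log units; that floor lies within the scatter), and it rests on a limit (the limit of > 1000 nM in this assay, at which 1 of the 3 values shown sits), so its true size is open beyond its floor. Compound 4 `Cc1ccc(NS(=O)(=O)c2ccc(N3CCNC3=O)cc2)cc1` differs from compound 3 by methyl in place of hexyloxy on an aromatic carbon. This change runs in the direction opposite to that step, and far further, since compound 1 with its shorter chain gives 580 nM. The number for compound 4 is therefore expected to fall well below the bound of compound 3, beyond the scatter. The expected step of an at least 6.6-fold lower number from compound 3 to compound 4 (0.82 log units; beyond the scatter) is estimated to lie beyond the scatter. Compound 4 is expected to give about 150 nM, between 40 nM and 600 nM.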

Compound 4, half-maximal inhibitory concentration: 260 nM
Estimate against measurement, compound 4: 1.7-fold (0.24 log units) below, and the stated range covers the measured number.
By their numbers in this assay, from the lowest: compound 2; then compound 4; then compound 1. At a limit, above all of these: compound 3.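

In this assay, within the data shown here, methyl in place of butoxy on this aromatic carbon gives a 2.2-fold lower number from compound 1 to compound 4 (0.35 log units; beyond the scatter), the first step at this position that has a number at both ends and lies beyond the scatter. Methyl in place of hexyloxy gives an at least 3.8-fold lower number from compound 3 to compound 4 (0.58 log units; beyond the scatter), so this floor, unlike that of the earlier step, clears the scatter, though the step rests on a limit and its true size stays open: the limit of > 1000 nM in this assay, at which 1 of the 4 values shown sits. Shortening the group does not by itself reach the lowest number shown, since 4-methylphenyl in place of 3-methoxyphenyl on the sulfonamide nitrogen gives a 4.0-fold higher number from compound 2 to compound 4 (0.60 log units; beyond the scatter).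

That last step changes both the group and its place on the ring, so the two effects cannot be separated here. From the compounds shown here alone, how a bare hydrogen, an amine or a carboxylic acid on this aromatic carbon would read remains open.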